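The compounds below may be only part of what the source reports. "The series", "measured", "known", "first", "only" and "open" are said of these compounds alone.

Measured so far:
- compound 1 `CNc1ncnc2c1c(-c1ccoc1)cn2[C@@H]1O[C@H](CO)[C@@H](O)[C@H]1O`: > 20000 nM
- compound 2 `Cc1ncnc2c1c(-c1cc3ccccc3o1)cn2[C@@H]1O[C@H](CO)[C@@H](O)[C@H]1O`: > 20000 nM
- compound 3 `COc1ncnc2c1c(-c1ccoc1)cn2[C@@H]1O[C@H](CO)[C@@H](O)[C@H]1O`: 290 nM

Among the compounds with values here, in a functional assay on HepG2 cells (Homo sapiens) for antiproliferative activity, read by XTT assay, with a stated time of 72 h (on this read-out lower numbers stand for stronger inhibition and higher numbers for weaker inhibition), compound 3 gives 290 nM and is the only compound of the three with a number rather than a limit. Compound 1 sits at a limit of the assay, > 20000 nM, not a number. Compound 2 also sits at a limit, > 20000 nM. Within the data shown here, the one step measured in one place is an at least 68-fold lower number from compound 1 to compound 3 (1.83 log units; beyond the scatter); its size rests on (the limit of > 20000 nM in this assay, at which 2 of the 3 values shown sit).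

Compound 4 `Cc1ncnc2c1c(-c1ccoc1)cn2[C@@H]1O[C@H](CO)[C@@H](O)[C@H]1O` differs from compound 3 as follows: methyl in place of methoxy on an aromatic carbon. The methyl enters at the position where the methoxy of compound 3 stood and the methylamino of compound 1 stood. The measured step of an at least 68-fold lower number from compound 1 to compound 3 (1.83 log units; beyond the scatter) shows that this position is sensitive in this assay, but it gives no direct reading for methyl. Compound 2, which carries a methyl at this position on a different aryl group, is at the limit of the assay. Taken together, a step to a weaker, higher number is expected, of the order of a 10-fold higher number from compound 3 to compound 4 (1.01 log units; beyond the scatter). Compound 4 is therefore estimated at 3000 nM, with a range from 500 nM to 20000 nM, and a real chance that only a limit is reported.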

Compound 4, half-maximal inhibitory concentration: 5320 nM
Compound 4: the middle estimate sits 1.8-fold (0.25 log units) below what was measured, within the range that was stated.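

In this assay, this position now has a step with a number at both ends: an 18-fold higher number from compound 3 to compound 4 (1.26 log units; beyond the scatter), so methyl in place of methoxy on this aromatic carbon gives a large move to weaker inhibition. Methyl still reads better than methylamino on the furan-3-yl compounds, an at least 3.7-fold lower number from compound 1 to compound 4 (0.57 log units; beyond the scatter), which places the three groups in the order methoxy, methyl, methylamino across compound 3, compound 4 and compound 1. With methyl held constant, the aryl group also matters, an at least 3.7-fold lower number from compound 2 to compound 4 (0.57 log units; beyond the scatter), but this step and the one from compound 1 give only the smallest possible size, and their true sizes cannot be read: the limit of > 20000 nM in this assay, at which 2 of the 4 values shown sit.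

The compounds shown leave open how a primary amine, an ethoxy group or a longer alkoxy chain would read at this position, so it cannot be told whether methoxy is a peak or one point on a wider trend. It also stays open whether the step from methoxy to methyl carries over to the 1-benzofuran-2-yl compounds, since among the compounds shown only furan-3-yl appears with both groups.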